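The source may hold more compounds than are shown below. What is called first, only, known or untested is meant among the compounds shown, and "the series" means these compounds.

Of the compounds shown here, three have been read so far in a functional assay on HCT-116 cells (Homo sapiens) for inhibition, read by MTT assay, with a stated time of 48 h; a higher number here means a weaker inhibitor, a lower number a stronger inhibitor. Compound 1 `COc1cc(NCc2ccccc2)cc(OC)c1OC` gives > 80000 nM, which is a limit of the assay and not a number. Compound 3 `COc1ccc(CNc2cc(OC)c(OC)c(OC)c2)cc1F` gives 32200 nM. Compound 2 `C#CC(=O)N(Cc1ccc(OC)c(O)c1)c1cc(OC)c(OC)c(OC)c1` gives 310 nM, the lower of the two actual numbers, and its gap to compound 3 lies well beyond the scatter. Among the compounds with values here, compound 2 is also the only measured compound with a carbonyl on the amide-type nitrogen. However, it differs from compound 1 and compound 3 in more than one place, so no single change can be credited with the gap.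

The next compound is compound 4 `COc1ccc(CN(C(=O)CN=[N+]=[N-])c2cc(OC)c(OC)c(OC)c2)cc1O`, with azidomethyl in place of ethynyl on a carbonyl carbon. The rest of compound 2 is unchanged. Within the data shown here, no measured pair differs in one place, so this change has no direct calibration. Compound 4 keeps the carbonyl, so the expectation is anchored on compound 2 at 310 nM, with a wide margin. The expected change in this assay is small, a 1.1-fold higher number from compound 2 to compound 4 (0.05 log units; within the scatter), with no firm direction and probably within the scatter. For compound 4 the estimated value is 350 nM, with an expected range of 70 nM to 1800 nM.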

Compound 4, half-maximal inhibitory concentration: 410 nM
For compound 4 the middle estimate is 1.2-fold (0.07 log units) below the measured one; measured number inside the range.
By their numbers in this assay, from the lowest: compounds 2 and 4 (each within the scatter of the next); then compound 3. At a limit, above all of these: compound 1.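

In this assay, within the data shown here, the change on the carbonyl carbon whose other neighbour is the amide-type nitrogen gives a 1.3-fold higher number from compound 2 to compound 4 (0.12 log units; within the scatter), the first step that can be read at one place. Ethynyl and azidomethyl therefore give values within the scatter at this position, although azidomethyl has more heavy atoms, no triple bond and a hydrogen-bond acceptor that ethynyl lacks. In this pair, a number of this size does not depend on the ethynyl group, and the step gives no reason to rank either group above the other.

Going by these compounds, whether a plain methyl, an aminomethyl, a carboxylic acid or a longer chain on the same carbonyl carbon would read alike remains open, as does whether the carbonyl itself accounts for the gap to compound 3, which differs from compound 2 in more than one place. Compound 1 gives a limit of the assay and not a number: the limit of > 80000 nM in this assay, at which 1 of the 4 values shown sits.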